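Moving the aryl group on nitrogen at the assay limit

The source may report more compounds than this note shows. Statements on the series, on what has been measured and on what is new or still open speak of the compounds shown alone.

- compound 1 `Fc1cccc(-c2nc(Nc3cccc(Cl)c3)c3cc(F)ccc3n2)c1`: > 50000 nM (a limit)
- compound 2 `Fc1cccc(-c2nc(Nc3ccc(Br)cc3)c3cc(F)ccc3n2)c1`: > 50000 nM (a limit)
- compound 3 `Fc1cccc(-c2nc(Nc3ccccc3Br)c3cc(F)ccc3n2)c1`: > 50000 nM (a limit)

In a functional assay on MDA-MB-231 cells (Homo sapiens) for cytotoxicity, read by MTT assay, with a stated time of 48 h (a higher number here means a weaker inhibitor, a lower number a stronger inhibitor), compound 3 gives > 50000 nM as a limit and not as a number. The measured set shows the limit of > 50000 nM in this assay, at which 3 of the 3 values shown sit, and no ranking of its members follows from that.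

The next compound is compound 4 `Cc1ccc(Nc2nc(-c3cccc(F)c3)nc3ccc(F)cc23)cc1`. The change is 4-methylphenyl in place of 2-bromophenyl on a nitrogen on an aromatic ring, with 4-methylphenyl in place of 2-bromophenyl on a nitrogen on an aromatic ring.

Going by the values given here, three measured steps concern this same place: a step that the two limits leave unreadable from compound 1 to compound 2, a step that the two limits leave unreadable from compound 1 to compound 3 and a step that the two limits leave unreadable from compound 2 to compound 3. None of them has a size that can be read, so they give no direction for the new step. Compound 2, with its 4-bromophenyl group, gives > 50000 nM as a limit, and this is the nearest ground for expecting compound 4 to stay weak.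

In this assay no clear step is expected, and the estimated change is a step that the limit leaves unreadable from compound 3 to compound 4 as a rough figure only. A report of a limit is the likeliest outcome. The estimate for compound 4 is 60000 nM, with an expected range from 25000 nM to 100000 nM as the result.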

Compound 4, half-maximal inhibitory concentration: > 50000 nM
Compound 4 gave a limit, no number; the forecaster's own chance of this, stated with the estimate: 80%; the middle value is on the limit's open side.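

In this assay compound 4 gives > 50000 nM as a limit and not as a number. Its steps from compound 1, compound 2 and compound 3 cannot be read, since all four compounds share one limit: the limit of > 50000 nM in this assay, at which 4 of the 4 values shown sit.

The compounds shown leave open whether any aryl group on this nitrogen gives a value readable as a number.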